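The compounds below may be only part of what the source reports. "The series", "measured", "known", "first", "only" and "open" are said of these compounds alone.

Working notes on the series.

Compound 1 `COc1cc(-c2nnc(SCC(=O)c3ccccc3)n2N)cc(OC)c1OC` is the unsubstituted member. In a functional assay on HeLa cells (Homo sapiens) for antiproliferative activity, read by MTT assay, with a stated time of 48 h (a lower number here means a stronger inhibitor, a higher number a weaker inhibitor), compound 1 gives only a limit, > 100000 nM. For the measured compounds named here, compound 2 `COc1cc(-c2nnc(SCC(=O)c3ccc(Cl)cc3)n2N)cc(OC)c1OC` carries a chloro on the phenyl ring; in this assay compound 2 gives 13100 nM, the only number so far in this assay. The other entry, that of compound 1, is a limit (the limit of > 100000 nM in this assay, at which 1 of the 2 values shown sits). Going by the values given here, the step of an at least 7.6-fold lower number from compound 1 to compound 2 (0.88 log units; beyond the scatter) is the single measured step, and it is at least modest.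

Compound 3 `COc1cc(-c2nnc(SCC(=O)c3ccc(Br)cc3)n2N)cc(OC)c1OC` differs from compound 2 in one place: bromo in place of chloro on an aromatic carbon. Among the compounds with values here, no measured step exchanges one halogen for another, so the size of this step cannot be read from the series; the only measured step shows that a halogen at this position matters, not how chloro and bromo compare. The step is therefore expected to stay within the scatter, with a 1.3-fold lower number from compound 2 to compound 3 (0.12 log units; within the scatter) as the working expectation. For compound 3 the estimate in this assay is 10000 nM, within the range 3000 nM to 35000 nM.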

Compound 3, half-maximal inhibitory concentration: 10400 nM
For compound 3 the middle estimate is 1.0-fold (0.02 log units) below the measured one; the range from low to high includes it.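

In this assay the exchange of 4-chlorophenyl for 4-bromophenyl gives a 1.3-fold lower number from compound 2 to compound 3 (0.10 log units; within the scatter), so chloro and bromo cannot be told apart at this position. Bromo in place of hydrogen gives an at least 9.6-fold lower number from compound 1 to compound 3 (0.98 log units; beyond the scatter), so the gain first seen with chloro now appears with a second halogen, and compound 2 and compound 3 both hold it. That gain is a bound and not a size, since compound 1 stands at a limit: the limit of > 100000 nM in this assay, at which 1 of the 3 values shown sits.

The compounds shown carry only hydrogen, chloro and bromo at this place, so whether fluoro, a methoxy group or an amine would keep the gain remains open. Changes elsewhere on the shared core, such as a longer chain before the carbonyl, also lie outside what these compounds can show.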